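One Methoxy Returned to the Outer Aryl Ring

The compounds below may be only part of what the source reports. "The series", "measured", "known", "first", "only" and "open" are said of these compounds alone.

Compound 1, `COc1ccc(/C=C/C(=O)/C=C/c2ccc(OCc3cn(CCCCOc4cc(=O)oc5ccccc45)nn3)c(OC)c2)cc1OC`: 55% in a functional assay on HCT-116 cells (Homo sapiens) for inhibition, read by sulforhodamine B assay, with a stated time of 48 h, tested at 50 uM; on this read-out lower numbers stand for less inhibition of growth and higher numbers for more inhibition of growth at the one concentration tested
Compound 2, `COc1cc(/C=C/C(=O)/C=C/c2cccs2)ccc1OCc1cn(CCCCOc2cc(=O)oc3ccccc23)nn1`: 41%
Compound 3, `COc1cc(/C=C/C(=O)/C=C/c2ccccc2)ccc1OCc1cn(CCCCOc2cc(=O)oc3ccccc23)nn1`: 34%

Compound 3 shows the lowest number of the three. Compound 2 stands close to it, within the usual scatter of this assay, so no order between these two can be claimed. Compound 1 is clearly apart: from compound 1 to compound 3 the read-out fell a number 21 percentage points lower from compound 1 to compound 3 (beyond the scatter), when phenyl took the place of 3,4-dimethoxyphenyl on a double-bonded chain carbon bound to a double-bonded chain carbon.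

Compound 4, `COc1ccc(/C=C/C(=O)/C=C/c2ccc(OCc3cn(CCCCOc4cc(=O)oc5ccccc45)nn3)c(OC)c2)cc1`, reverses part of that change: methoxy in place of hydrogen on an aromatic carbon. The new group sits on an aromatic carbon of a six-membered aromatic ring of carbon only, para to a large group. Among the measured compounds shown here, the step that bears most directly on it is the one from compound 1 to compound 3, where removing both methoxy groups lowered the number beyond the scatter; the step from compound 1 to compound 2, a number 14 percentage points lower from compound 1 to compound 2 (beyond the scatter), points the same way. Returning a single methoxy is expected to recover only part of that loss.

Compound 4 is therefore expected to give 44% in this assay, with a likely range of 32% to 56%. The expected step from compound 3 is a number 10 percentage points higher from compound 3 to compound 4 (within the scatter), a modest rise that may still fall near the edge of the scatter.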

Compound 4, percent growth inhibition at one concentration: 40%
Beside the measured number, compound 4's estimate is 4 percentage points above it, within the range that was stated.
By their numbers in this assay, from the lowest: compounds 3, 4 and 2 (each within the scatter of the next); then compound 1.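

In this assay, among the compounds shown here, a single methoxy on the aromatic carbon para to a large group gives a number 6 percentage points higher from compound 3 to compound 4 (within the scatter) and so cannot be told apart from hydrogen at this place, which the earlier compounds could not show because they changed the whole ring at once. The larger difference appears with the other methoxy of the 3,4-dimethoxyphenyl group: hydrogen in its place gives a number 15 percentage points lower from compound 1 to compound 4 (beyond the scatter) and 4-methoxyphenyl in place of thiophen-2-yl gives a number 1 percentage points lower from compound 2 to compound 4 (within the scatter) so among these compounds only the ring carrying both methoxy groups stands apart. No available evidence explains why the two methoxy groups together separate compound 1 from the others.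

Whether the second methoxy would be enough without the one at this place remains open, since none of the compounds shown carries it alone. Also open, going by these compounds, is how a hydroxyl group, a fluorine atom or a dimethylamino group would read at this place, and whether any of these could match the two methoxy groups of compound 1.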